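Cycloalkyl groups on the carbonyl: working notes

The source may report more compounds than this note shows. Statements on the series, on what has been measured and on what is new or still open speak of the compounds shown alone.

compound 1 `O=C(C1CCCC1)N1N=CCC1c1ccccc1`: 0.2 h
compound 2 `C[C@@H]1C=NN(C(=O)C(C)(C)C)[C@@H]1c1ccccc1`: 0.2 h
compound 3 `O=C(C1CCC1)N1N=CCC1c1ccccc1`: 0.583 h

In an ADME assay on microsomes (Rattus norvegicus) for metabolic stability (a lower number here means that the compound disappears faster, a higher number that the compound lasts longer), compound 3 gives 0.583 h and stands highest of the three compounds. Compound 4 `O=C(C1CCCCC1)N1N=CCC1c1ccccc1` carries cyclohexyl in place of cyclobutyl on a carbonyl carbon. Among the compounds with values here, the one measured step at this place is a 2.9-fold higher number from compound 1 to compound 3 (0.46 log units; beyond the scatter) with cyclobutyl in place of cyclopentyl. A single step makes no trend, and cyclohexyl itself is unmeasured. Even so, compound 4 is expected to fall back towards compound 1 rather than hold the number of compound 3. The expected change is a 3.2-fold lower number from compound 3 to compound 4 (0.51 log units; beyond the scatter) in the lower direction. The estimate for compound 4 is 0.18 h with an expected range from 0.08 h to 0.4 h in this assay.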

Compound 4, half-life: 0.0833 h
Beside the measured number, compound 4's estimate is 2.2-fold (0.33 log units) above it; the range from low to high includes it.
By their numbers in this assay, from the lowest: compound 4; then compounds 1 and 2 (each within the scatter of the next); then compound 3.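

In this assay cyclohexyl on a carbonyl carbon gives a 7.0-fold lower number from compound 3 to compound 4 (0.85 log units; beyond the scatter) and a 2.4-fold lower number from compound 1 to compound 4 (0.38 log units; beyond the scatter) with each step beyond the scatter. The three cycloalkyl compounds now fall in one order, with cyclobutyl highest, cyclopentyl lower and cyclohexyl lowest, and none of the three goes against it. Nothing at hand explains why the half-life follows this order.

Open, on these data alone, is where cyclopropyl would stand in this order. Also open, as far as these compounds go, is whether an amine or a hydroxyl group on the cyclohexyl ring would raise the number of compound 4.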